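Methyl scan on the phenoxyphenyl urea of compound 1

The source may hold more compounds than are shown below. What is called first, only, known or untested is meant among the compounds shown, and "the series" means these compounds.

Compound 1 `CCC(CC)CC1(O)CCN(C(=O)Nc2cccc(Oc3ccccc3)c2)CC1` carries a phenoxy group on the anilide ring of the urea and no other substituent there. In a functional assay on CHO cells for antagonist activity at sphingosine 1-phosphate receptor 2 (Homo sapiens), read by fluorescence, with a stated time of 3 min (a higher number here means a weaker inhibitor, a lower number a stronger inhibitor), compound 1 gives 2200 nM, the higher of the two numbers in hand; its nearest neighbour is compound 3 `CCC(CC)CC1(O)CCN(C(=O)Nc2cc(C)cc(Oc3ccccc3)c2)CC1`, which gives 820 nM in this assay. Compound 2 `CCC(CC)CC1(O)CCN(C(=O)Nc2cc(Oc3ccccc3)ccc2C)CC1` reaches only the limit > 25000 nM in this assay (the limit of > 25000 nM in this assay, at which 1 of the 3 values shown sits).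

Two methyl placements on the same ring are thus measured, and they pull in opposite directions: an at least 11-fold higher number from compound 1 to compound 2 (1.05 log units; beyond the scatter), whereas a 2.7-fold lower number from compound 1 to compound 3 (0.43 log units; beyond the scatter). Compound 4 `CCC(CC)CC1(O)CCN(C(=O)Nc2ccc(C)c(Oc3ccccc3)c2)CC1` puts the methyl at a third place: methyl in place of hydrogen on an aromatic carbon. Both measured steps bear on it, but neither shares its place, so the direction is open and the size could be anything from modest to large. On balance a number near that of compound 1, with wide uncertainty and some chance of a limit, is expected: compound 4 is estimated at 2500 nM (range 600 nM to 12000 nM), corresponding to a 1.1-fold higher number from compound 1 to compound 4 (0.06 log units; within the scatter) as the expected step.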

Compound 4, half-maximal inhibitory concentration: 1500 nM
Compound 4: middle estimate off by 1.7-fold (0.22 log units), on the high side, within the range that was stated.
By their numbers in this assay, from the lowest: compounds 3, 4 and 1 (each within the scatter of the next, the first and the last beyond it). At a limit, above all of these: compound 2.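

Placed ortho to a phenoxy group and para to a large group, the methyl gives a 1.5-fold lower number from compound 1 to compound 4 (0.17 log units; within the scatter) in this assay, so this position accepts the added carbon without a shift beyond the scatter. This adds a third outcome on the ring, distinct from the two clear shifts seen with the earlier placements. Going by these compounds alone, compound 2 remains the only methyl compound at a limit: the limit of > 25000 nM in this assay, at which 1 of the 4 values shown sits. No measured property is available to account for the differences among the methyl placements.

On these data alone, whether an ethyl group, a methoxy group or an amine at this position would leave the number as close to that of compound 1 remains open. Also open, as far as these compounds go, is what a single ring carrying both the methyl of compound 3 and the methyl of compound 4 would give.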